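A Dimethoxyphenyl Isomer Awaiting Its Cytotoxicity Value

The compounds below may be only part of what the source reports. "The series", "measured", "known", "first", "only" and "open" are said of these compounds alone.

In a functional assay on A549 cells (Homo sapiens) for cytotoxicity, read by MTT assay, with a stated time of 72 h (on this read-out lower numbers stand for stronger inhibition and higher numbers for weaker inhibition), compound 1 `O=C(/C=C/c1ccc([N+](=O)[O-])cc1)Nc1cc2c(Nc3ccc(F)c(Cl)c3)ncnc2cc1O[C@H]1CCOC1` gives 12000 nM, compound 2 `COc1ccc(OC)c(/C=C/C(=O)Nc2cc3c(Nc4ccc(F)c(Cl)c4)ncnc3cc2OC)c1` gives 11200 nM and compound 3 `COc1ccc(OC)c(/C=C/C(=O)Nc2cc3c(Nc4ccc(F)c(Cl)c4)ncnc3cc2O[C@H]2CCOC2)c1` gives 7300 nM. Compound 2 lies within the scatter of both other compounds, so these three values do not separate. Compound 4 `COc1cc(/C=C/C(=O)Nc2cc3c(Nc4ccc(F)c(Cl)c4)ncnc3cc2OC)cc(OC)c1` has the same atoms as compound 2, joined differently: 3,5-dimethoxyphenyl in place of 2,5-dimethoxyphenyl on a double-bonded chain carbon bound to a double-bonded chain carbon. It carries 3,5-dimethoxyphenyl in place of 2,5-dimethoxyphenyl on a double-bonded chain carbon bound to a double-bonded chain carbon. At that same place, exchanging 4-nitrophenyl for 2,5-dimethoxyphenyl gave a 1.6-fold lower number from compound 1 to compound 3 (0.22 log units; within the scatter). The other measured step, oxolan-3-yl in place of methyl on an oxygen on an aromatic ring, gave a 1.5-fold lower number from compound 2 to compound 3 (0.19 log units; within the scatter) and bears on the question only indirectly. Among the measured compounds shown here, no measured compound carries 3,5-dimethoxyphenyl, so the data offer no direct test of this change. No step beyond the scatter is therefore expected in this assay, and the estimated step is a 1.1-fold lower number from compound 2 to compound 4 (0.05 log units; within the scatter). For compound 4 the expected value is 10000 nM, with an estimated range of 4500 nM to 22000 nM.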

Compound 4, half-maximal inhibitory concentration: "not active" (no number reported)
Compound 4 has no reported number here; the estimate stays without a comparison.
By their numbers in this assay, from the lowest: compounds 3, 2 and 1 (each within the scatter of the next).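

Among the compounds shown here, compound 4 is reported as "not active" in this assay with no number, so no step from compound 2 to compound 4 can be read. No measured evidence bears on this result. The compounds shown leave open how far 3,5-dimethoxyphenyl and 2,5-dimethoxyphenyl differ in this read-out.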